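The source may report more compounds than this note shows. Statements on the series, on what has been measured and on what is new or still open speak of the compounds shown alone.

Working notes on the series. Among the measured compounds shown here, compound 1 `O=C(CSC(=S)N[C@H]1CCOC1=O)Nc1ccc(O)cc1` and compound 2 `CCSC(=S)N[C@H]1CCOC1=O` are the first two entries. In a functional assay on EC9706 cells (Homo sapiens) for cytotoxicity, read by MTT assay, with a stated time of 72 h (on this read-out lower numbers stand for stronger inhibition and higher numbers for weaker inhibition), compound 1 gives > 128000 nM, which is a limit of the assay and not a number. In this assay compound 2 likewise gives > 128000 nM, again a limit rather than a number. Compound 3 `O=C(CCl)Nc1ccc(C(=O)/C=C/c2ccc(F)cc2)cc1` is the only entry with a measured figure: in this assay compound 3 gives 8600 nM. Where compound 3 stands is therefore simple to state: it holds the single number in the set, while the other two entries sit at the limit of > 128000 nM in this assay, at which 2 of the 3 values shown sit.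

Compound 4 `Cc1ccc(/C=C/C(=O)c2ccc(NC(=O)CCl)cc2)cc1` has not yet been measured. It differs from compound 3 by methyl in place of fluoro on an aromatic carbon. For the measured compounds named here, no measured step of this kind exists within the set, so the expected change from compound 3 to compound 4 in this assay is a 1.1-fold lower number from compound 3 to compound 4 (0.03 log units; within the scatter), which is not expected to exceed the usual scatter in either direction. For compound 4 the estimated value in this assay is 8000 nM, with a range from 3000 nM to 22000 nM.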

Compound 4, half-maximal inhibitory concentration: 7150 nM
Beside the measured number, compound 4's estimate is 1.1-fold (0.05 log units) above it; the measured number falls inside the stated range.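

In this assay, among the compounds shown here, the exchange of 4-fluorophenyl to 4-methylphenyl, methyl in place of fluoro on an aromatic carbon para to a large group, gives a 1.2-fold lower number from compound 3 to compound 4 (0.08 log units; within the scatter), the first step that can be read. On this single pair, the position takes either fluoro or methyl without a shift beyond the scatter, so the two groups cannot be told apart by this read-out. Nothing measured in the series bears on a cause for this step.

As far as these compounds go, whether an amine, a carboxylic acid or a longer chain at this position would move the number beyond the scatter remains open. Also open, from the compounds shown here alone, is whether methyl in place of fluoro gives a similar step at another position on this ring or on a different core.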